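The compounds below may be only part of what the source reports. "The series", "measured", "known", "first", "only" and "open" are said of these compounds alone.

Compound 3 `Cc1c(C(=O)/C=C/c2ccc(Cl)c(Cl)c2)[n+]([O-])c2ccccc2[n+]1[O-]` gives 10100 nM in a functional assay on MOLT-4 cells (Homo sapiens) for inhibition, with a stated time of 3 days; a lower number here means a stronger inhibitor, a higher number a weaker inhibitor. Among the three measured compounds it holds the second highest number: compound 2 `Cc1c(C(=O)/C=C/c2ccc(Cl)cc2)[n+]([O-])c2ccccc2[n+]1[O-]` gives 7750 nM in this assay, compound 1 `COc1ccc(/C=C/C(=O)c2c(C)[n+]([O-])c3ccccc3[n+]2[O-])cc1OC` gives 18500 nM in this assay, and both differ from compound 3 only within the scatter. Compound 4 `Cc1c(C(=O)/C=C/c2ccc(F)cc2)[n+]([O-])c2ccccc2[n+]1[O-]` differs from compound 3 by 4-fluorophenyl in place of 3,4-dichlorophenyl on a double-bonded chain carbon bound to a double-bonded chain carbon. Among the measured compounds shown here, the only measured step touching this part of the structure is a 1.3-fold higher number from compound 2 to compound 3 (0.12 log units; within the scatter), which stayed within the scatter; no measured pair shows fluorine in place of chlorine. Because compound 3 gives 10100 nM and the other two measured numbers differ from it only within the scatter, the expected step of a 1.0-fold lower number from compound 3 to compound 4 (0.00 log units; within the scatter) is judged to stay within the scatter, with no clear direction. Compound 4 is therefore estimated at 10000 nM, with a range from 4000 nM to 25000 nM.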

Compound 4, half-maximal inhibitory concentration: 6400 nM
Compound 4: middle estimate off by 1.6-fold (0.19 log units), on the high side; the range from low to high includes it.
By their numbers in this assay, from the lowest: compounds 4, 2, 3 and 1 (each within the scatter of the next, the first and the last beyond it).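

In this assay, the change to 4-fluorophenyl on a double-bonded chain carbon bound to a double-bonded chain carbon gives a 1.6-fold lower number from compound 3 to compound 4 (0.20 log units; within the scatter) and fluoro in place of chloro on an aromatic carbon gives a 1.2-fold lower number from compound 2 to compound 4 (0.08 log units; within the scatter). Thus replacing chlorine with fluorine, the first such pair, also leaves the number unchanged beyond the scatter, as did adding the second chloro. No measurement available here explains these steps. On these data alone, whether an amine or a carboxylic acid on this phenyl ring would move the number beyond the scatter remains open, as does the result for plain phenyl.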